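Trimethoxyphenyl to chlorophenyl on a shared core

A few compounds are considered here, and "the series" means these few. Any claim that something is new, unique, unknown or untested is made for them only; others in the source may bear on it.

Of the compounds shown here, two have been measured in a functional assay on COLO 205 cells (Homo sapiens) for inhibition, read by sulforhodamine B assay, tested at 10 uM; a lower number here means less inhibition of growth, a higher number more inhibition of growth at the concentration tested. Compound 1, `COc1cc(C2CC(c3ccc(OCc4cn(Cc5ccc([N+](=O)[O-])cc5)nn4)cc3)=NN2C(C)=O)ccc1Oc1cn(Cc2ccc([N+](=O)[O-])cc2)nn1`, gives 27% in this assay. Compound 2, `COc1cc(C2CC(c3cc(OC)c(OC)c(OC)c3)=NN2C(C)=O)ccc1OCc1cn(Cc2ccc([N+](=O)[O-])cc2)nn1`, gives 60% in this assay. Compound 2 therefore holds the higher of the two numbers, and its gap to compound 1 lies beyond the usual scatter; the two differ in several places at once, so their readings can only be set side by side. Compound 3, `COc1cc(C2CC(c3ccc(Cl)cc3)=NN2C(C)=O)ccc1OCc1cn(Cc2ccc([N+](=O)[O-])cc2)nn1`, is not yet measured. It differs from compound 2 in one place: 4-chlorophenyl in place of 3,4,5-trimethoxyphenyl on a carbon with a double bond to nitrogen. Among the compounds with values here, no measured pair isolates this change, so the direction rests on expectation alone. A moderate fall is expected, a number 18 percentage points lower from compound 2 to compound 3 (beyond the scatter), reaching beyond the scatter yet leaving clear growth inhibition. For compound 3 the estimate is 42%, within a range from 18% to 65%.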

Compound 3, percent growth inhibition at one concentration: 0%
Compound 3: the middle estimate sits 42 percentage points above what was measured; the whole stated range lies above it.
By their numbers in this assay, from the lowest: compound 3; then compound 1; then compound 2.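

Within the data shown here, replacing 3,4,5-trimethoxyphenyl with 4-chlorophenyl on the carbon with a double bond to nitrogen gives, in this assay, a number 60 percentage points lower from compound 2 to compound 3 (beyond the scatter), the first reading of a single change at this position. Compound 3 gives 0%, so the growth inhibition seen with compound 2 does not persist, even though the six-membered aromatic ring of carbon is kept and only what it carries differs. No independent measurement here bears on why the reading falls.

Going by these compounds, the change removes the three methoxy groups and adds a chlorine in one step, so the share of each in the loss stays open. An unsubstituted phenyl group or a 4-methoxyphenyl group at this carbon would separate the two.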